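Working notes: amino in place of hydroxy, four compounds

The source may hold more compounds than are shown below. What is called first, only, known or untested is meant among the compounds shown, and "the series" means these compounds.

Measured so far:
- compound 1 `Oc1cccc(/C=C/c2cccc(O)c2)c1`: 21 ug/mL in an ADME assay on HEK293 cells (Homo sapiens) for inhibition, read by MTT assay, with a stated time of 2 days; on this read-out lower numbers stand for stronger inhibition and higher numbers for weaker inhibition
- compound 2 `Oc1ccc(/C=C/c2cccc(O)c2)cc1`: 1.1 ug/mL in this assay
- compound 3 `Nc1cccc(/C=C/c2cccc(O)c2)c1`: the result in this assay is a limit of the assay, > 100 ug/mL

Compound 1 and compound 2 have the same atoms joined differently; the difference between the two cores is not broken down here. Of the two numbers, compound 2 gives the lower one.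

From compound 1 to compound 3 the change is amino in place of hydroxy on an aromatic carbon and the step is an at least 4.7-fold higher number from compound 1 to compound 3 (0.67 log units; beyond the scatter). This rests on (the limit of > 100 ug/mL in this assay, at which 1 of the 3 values shown sits), so the step is a floor, not a size.

Compound 4 `Nc1cccc(/C=C/c2ccc(O)cc2)c1` carries the same change against compound 2: amino in place of hydroxy on an aromatic carbon. Given an at least 4.7-fold higher number from compound 1 to compound 3 (0.67 log units; beyond the scatter), an expected step of at least similar size, a 14-fold higher number from compound 2 to compound 4 (1.13 log units; beyond the scatter), is taken for compound 4. Compound 4 is therefore expected at 15 ug/mL, plausibly between 4 ug/mL and 80 ug/mL.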

Compound 4, half-maximal inhibitory concentration: 7 ug/mL
For compound 4 the middle estimate is 2.1-fold (0.33 log units) above the measured one; low and high end bracket the measured number.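

Amino in place of hydroxy also gives a higher number on the second core: in this assay the step is a 6.4-fold higher number from compound 2 to compound 4 (0.80 log units; beyond the scatter). Both steps point the same way, so the direction carries across these two cores, but whether its size carries over cannot be read: the same change on two cores in this assay, an at least 4.7-fold higher number (0.67 log units; beyond the scatter) from compound 1 to compound 3 and a 6.4-fold higher number (0.80 log units; beyond the scatter) from compound 2 to compound 4; the limit leaves it open whether they differ

Compound 3 sits at a limit of the assay, so its step is a floor and not a size: the limit of > 100 ug/mL in this assay, at which 1 of the 4 values shown sits.

From the compounds shown here alone, it remains open whether the same direction holds on any core beyond these two. Also open, going by these compounds, is how other groups in the place of the hydroxy, such as a methoxy, a dimethylamino or a carboxylic acid, would read on either core.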